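Replacing 2-iodophenyl with 2,5-dimethoxyphenyl at the assay limit

The compounds below may be only part of what the source reports. "The series", "measured", "known", "first", "only" and "open" are said of these compounds alone.

Measured in a functional assay on HCT-116 cells (Homo sapiens) for antiproliferative activity, with a stated time of 72 h; on this read-out lower numbers stand for stronger inhibition and higher numbers for weaker inhibition:
- Compound 1 `CC(=O)Oc1ccccc1/C=C/c1nc2ccccc2c(=O)[nH]1`: > 25000 nM (a limit)
- Compound 2 `CC(=O)Oc1ccccc1/C=C/c1nc(Nc2ccccc2I)c2ccccc2n1`: > 25000 nM (a limit)

Compound 2 sits at the limit of > 25000 nM in this assay, at which 2 of the 2 values shown sit. On these data alone, this reading is a limit and not a number, so the true potency of compound 2 remains unknown. It shows only that no half-maximal inhibitory concentration was obtained within the tested range.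

Compound 3 `COc1ccc(OC)c(Nc2nc(/C=C/c3ccccc3OC(C)=O)nc3ccccc23)c1` has 2,5-dimethoxyphenyl in place of 2-iodophenyl on a nitrogen on an aromatic ring. The change adds 2 hydrogen-bond acceptors and replaces the iodine with oxygen-bearing groups.

Going by the values given here, no pair of measured compounds shows what a change of this kind does in this assay, so the expectation is loose. A modest gain in inhibition seems possible, but compound 3 may equally stay at the limit. The estimate means an expected step of an at least 1.6-fold lower number from compound 2 to compound 3 (0.22 log units; that floor lies within the scatter), towards stronger inhibition. For compound 3 the estimated value is 15000 nM, with an expected range of 4000 nM to 25000 nM.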

Compound 3, half-maximal inhibitory concentration: > 25000 nM
Compound 3: only a limit was reported; the forecaster's own chance of this, stated with the estimate: 55%; middle value at least 1.6-fold (0.22 log units) away from the limit.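

In this assay compound 3 gives > 25000 nM, a limit and not a number. No step can be read from compound 2 to compound 3, because both stand at a limit: the limit of > 25000 nM in this assay, at which 3 of the 3 values shown sit.

The compounds shown leave open how strongly each one inhibits, and whether 2,5-dimethoxyphenyl in place of 2-iodophenyl changes the read-out at all.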